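A methoxy group added to compound 2

The source may hold more compounds than are shown below. What is called first, only, known or untested is meant among the compounds shown, and "the series" means these compounds.

Measured in a functional assay on SF-268 cells (Homo sapiens) for antiproliferative activity, read by sulforhodamine B assay, with a stated time of 72 h (on this read-out lower numbers stand for stronger inhibition and higher numbers for weaker inhibition), so far:
Compound 1 `CCN1C(=O)CS/C1=N/Nc1nncc2ccccc12` gives 6 nM
Compound 2 `S=C(NNc1nncc2ccccc12)Nc1ccccc1` gives 57 nM
Compound 3 `Clc1ccc(C(/C=C/c2ccccc2)=N\Nc2nncc3ccccc23)cc1` gives 6.3 nM

Compound 2 has the highest number of the three, so it is the weakest inhibitor here, and its gaps to compound 1 and compound 3 are both beyond the scatter. Compound 4 `COc1ccc(NC(=S)NNc2nncc3ccccc23)cc1` is compound 2 with methoxy in place of hydrogen on an aromatic carbon, para to a large group (methoxy in place of hydrogen on an aromatic carbon). Going by the values given here, no measured pair shows this change. Starting from compound 2 at 57 nM only a modest downward move is expected in this assay and possibly none beyond the scatter. The estimated change is a 1.4-fold lower number from compound 2 to compound 4 (0.15 log units; within the scatter) and remains only an expectation. The estimate for compound 4 is 40 nM (range 12 nM to 130 nM).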

Compound 4, half-maximal inhibitory concentration: 86 nM
Beside the measured number, compound 4's estimate is 2.2-fold (0.33 log units) below it; the range from low to high includes it.
By their numbers in this assay, from the lowest: compounds 1 and 3 (each within the scatter of the next); then compounds 2 and 4 (each within the scatter of the next).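

Going by these compounds alone, for the first time, a change on the aromatic ring of compound 2 can be read: on the carbon para to a large group, methoxy in place of hydrogen gives a 1.5-fold higher number from compound 2 to compound 4 (0.18 log units; within the scatter) in this assay on this read-out. This position therefore accepts methoxy, with its 2 heavy atoms and 1 hydrogen-bond acceptor, with no difference beyond the usual scatter. Nothing measured here explains this result.

On these data alone, whether an amine or a carboxylic acid on this same carbon would also stay within the scatter remains open. So does the effect of a longer chain, such as butoxy, in this place.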